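Swapping the pyrazolyloxy group for a triazolyl sulfide

The source may hold more compounds than are shown below. What is called first, only, known or untested is meant among the compounds shown, and "the series" means these compounds.

Compounds measured so far in a functional assay on Jurkat cells (Homo sapiens) for inhibition; a higher number here means a weaker inhibitor, a lower number a stronger inhibitor:
- compound 1, `CC(C)[C@H](NC(=O)COc1cccc2ccccc12)C(=O)N[C@@H](CC(=O)O)C(=O)COc1cc(C(F)(F)F)n(C)n1`: 46000 nM
- compound 2, `CCOC(=O)c1c(C)noc1OCC(=O)[C@H](CC(=O)O)NC(=O)[C@@H](NC(=O)COc1cccc2ccccc12)C(C)C`: a limit of the assay, > 200000 nM
- compound 3, `CC(C)[C@H](NC(=O)COc1cccc2ccccc12)C(=O)N[C@@H](CC(=O)O)C(=O)CSc1nnc(-c2ccccc2)o1`: 150000 nM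

Compound 1 gives the lowest of the two numbers; compound 3 sits nearest, and the step of a 3.3-fold higher number from compound 1 to compound 3 (0.51 log units; beyond the scatter) lies beyond the scatter. Compound 2 reaches only the limit (the limit of > 200000 nM in this assay, at which 1 of the 3 values shown sits), and the step of an at least 4.3-fold higher number from compound 1 to compound 2 (0.63 log units; beyond the scatter) is at least modest.

Compound 4, `CC(C)[C@H](NC(=O)COc1cccc2ccccc12)C(=O)N[C@@H](CC(=O)O)C(=O)CSc1nncn1C`, differs from compound 1 at a single place: (4-methyl-4H-1,2,4-triazol-3-yl)sulfanyl in place of (1-methyl-5-(trifluoromethyl)-1H-pyrazol-3-yl)oxy on a saturated chain carbon bound to a carbonyl carbon. Going by the values given here, two measured steps bear on this change, as both also replace the pyrazolyloxy group of compound 1 at the same saturated chain carbon: a 3.3-fold higher number from compound 1 to compound 3 (0.51 log units; beyond the scatter), which likewise introduces a sulfanyl-linked five-membered ring, and an at least 4.3-fold higher number from compound 1 to compound 2 (0.63 log units; beyond the scatter). Both point the same way, toward a higher number in this assay. Compound 4 is therefore expected to give a modestly higher number than compound 1, a step of about a 3.0-fold higher number from compound 1 to compound 4 (0.48 log units; beyond the scatter). The estimate for compound 4 is 140000 nM, with a range from 60000 nM to 300000 nM.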

Compound 4, half-maximal inhibitory concentration: > 200000 nM
Compound 4 gave a limit, no number; the forecaster's own chance of this, stated with the estimate: 25%; middle value at least 1.4-fold (0.15 log units) from the limit.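

Compound 4 reaches a limit of the assay and gives no number: the limit of > 200000 nM in this assay, at which 2 of the 4 values shown sit.

The change gives an at least 4.3-fold higher number from compound 1 to compound 4 (0.63 log units; beyond the scatter), so all three replacements of the pyrazolyloxy group shown on this saturated chain carbon move to a higher number, and none goes against that, now including a replacement with fewer heavy atoms than the group it displaces. On the sulfur, 4-methyl-4H-1,2,4-triazol-3-yl in place of 5-phenyl-1,3,4-oxadiazol-2-yl gives an at least 1.3-fold higher number from compound 3 to compound 4 (0.12 log units; that floor lies within the scatter), which leaves the two sulfides unordered, and the steps between the limits of compound 2 and compound 4 cannot be read.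

Still open, going by these compounds, is whether the oxygen link, the ring or the trifluoromethyl accounts for the lower number of compound 1, since link and ring change together in compound 3 and compound 4. A nitrile in place of the trifluoromethyl would test one of these parts alone.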